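Notes on the step from compound 3 to compound 4

A few compounds are considered here, and "the series" means these few. Any claim that something is new, unique, unknown or untested is made for them only; others in the source may bear on it.

- compound 1 `Cc1ccc(CS/C(=C/c2ccc(O)cc2)C(=O)c2ccc(Cl)cc2)cc1`: 10000 nM
- compound 2 `Cc1ccc(CS/C(=C/c2ccccc2F)C(=O)c2ccc(Cl)cc2)cc1`: 10000 nM
- compound 3 `Cc1ccc(CS/C(=C/c2cc(Cl)cc(Cl)c2)C(=O)c2ccc(Cl)cc2)cc1`: 10000 nM

In a functional assay on DU-145 cells (Homo sapiens) for inhibition, read by trypan blue exclusion, with a stated time of 96 h (on this read-out lower numbers stand for stronger inhibition of growth and higher numbers for weaker inhibition of growth), compound 3 gives 10000 nM, level with compound 1 and compound 2. Compound 4 `Cc1ccc(CS/C(=C/c2ccc(Cl)cc2)C(=O)c2ccc(Cl)cc2)cc1` has not yet been measured. It carries 4-chlorophenyl in place of 3,5-dichlorophenyl on a double-bonded chain carbon bound to a double-bonded chain carbon.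

All three measured steps change the group at this same place: no change at the digits printed from compound 1 to compound 2 (within the scatter), no change at the digits printed from compound 1 to compound 3 (within the scatter) and no change at the digits printed from compound 2 to compound 3 (within the scatter). The last two start from or end at compound 3 and bear most directly on the new step. None of the three leaves the scatter, so the series offers no trend to extend. Among the measured compounds shown here, no measured compound carries 4-chlorophenyl at this place, so that group remains untested.

In this assay no change beyond the scatter is therefore expected, and the estimated step is no change at the digits printed from compound 3 to compound 4 (within the scatter). Compound 4 is expected at 10000 nM, with an estimated range of 3000 nM to 14000 nM.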

Compound 4, concentration for 50% growth inhibition: 10000 nM
Compound 4: middle estimate and measured number agree at the digits printed; the range from low to high includes it.
By their numbers in this assay, from the lowest: compounds 1, 2, 3 and 4 (each within the scatter of the next).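

In this assay, 4-chlorophenyl on a double-bonded chain carbon bound to a double-bonded chain carbon gives no change at the digits printed from compound 3 to compound 4 (within the scatter) when it replaces 3,5-dichlorophenyl and no change at the digits printed from compound 2 to compound 4 (within the scatter) when it replaces 2-fluorophenyl, so a fourth aryl group joins the flat set at this place. Among the compounds shown here, the direct swap of chloro in place of hydroxy on an aromatic carbon, a change the earlier compounds did not include, gives no change at the digits printed from compound 1 to compound 4 (within the scatter). No supporting data bear on this result.

Open, from the compounds shown here alone, is whether an amine or a carboxylic acid on the phenyl ring, or a longer chain in place of the aryl group, would shift the read-out at this place. The compounds shown also vary only this place, so the effect of changes elsewhere on the shared core remains unknown.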